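A few compounds are considered here, and "the series" means these few. Any claim that something is new, unique, unknown or untested is made for them only; others in the source may bear on it.

Measured compounds in an assay on isolated protein for inhibition of NEDD8-activating enzyme E1 regulatory subunit (Homo sapiens), read by Western blot, with stated times of 10 min and 30 min, tested at 25 uM; on this read-out lower numbers stand for less inhibition and higher numbers for more inhibition at the one concentration tested (going by the name of the read-out):
- compound 1, `CCCNC(=O)c1cccc2nc(OCC)n(Cc3ccc(-c4ccccc4-c4nnn[nH]4)cc3)c12`, giving 32.6%
- compound 2, `CCOc1nc2cccc(C(=O)NCCCOC)c2n1Cc1ccc(-c2ccccc2-c2nnn[nH]2)cc1`, giving 27.9%
- compound 3, `CCOc1nc2cccc(C(=O)Nc3ccc(S(N)(=O)=O)cc3)c2n1Cc1ccc(-c2ccccc2-c2nnn[nH]2)cc1`, giving 60.9%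

Compound 3 stands highest of the three numbers in this assay, with the others beyond the scatter below it. The two steps that lead to it are a number 28.3 percentage points higher from compound 1 to compound 3 (beyond the scatter) and a number 33 percentage points higher from compound 2 to compound 3 (beyond the scatter), whereas a number 4.7 percentage points lower from compound 1 to compound 2 (within the scatter) shows that the two chain-bearing amides are not distinguished. Compound 4, `CCOc1nc2cccc(C(=O)NCc3ccco3)c2n1Cc1ccc(-c2ccccc2-c2nnn[nH]2)cc1`, is the next compound to be measured. It differs from compound 3 in this way: (furan-2-yl)methyl in place of 4-sulfamoylphenyl on an amide-type nitrogen. Both steps into compound 3 were gains when the 4-sulfamoylphenyl took the place of a chain on the amide-type nitrogen, so its removal in compound 4 is expected to reverse some of that gain, without a direct precedent for the (furan-2-yl)methyl group. For compound 4 the expected step is a number 22.9 percentage points lower from compound 3 to compound 4 (beyond the scatter), a fall beyond the scatter. Compound 4 is therefore estimated at 38% in this assay, in the range 22% to 58%.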

Compound 4, a percentage reported as inhibition, at one concentration (the size of the read-out at that concentration, not a potency): 37.5%
Estimate against measurement, compound 4: 0.5 percentage points above; the measured number falls inside the stated range.
By their numbers in this assay, from the lowest: compounds 2, 1 and 4 (each within the scatter of the next); then compound 3.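

In this assay, the (furan-2-yl)methyl group on the amide-type nitrogen does not match the 4-sulfamoylphenyl, with a number 23.4 percentage points lower from compound 3 to compound 4 (beyond the scatter), so an aromatic ring at this place does not by itself carry the higher number. Compound 4 is also not distinguished from the amides bearing open chains, with a number 9.6 percentage points higher from compound 2 to compound 4 (within the scatter) and a number 4.9 percentage points higher from compound 1 to compound 4 (within the scatter), which leaves compound 3 alone above the other three. No measurement shown here bears on why the number shifts with this change.

As far as these compounds go, the step from compound 3 to compound 4 alters the ring, the sulfamoyl group and the carbon link at once, so the part responsible stays open. A plain phenyl or a 4-sulfamoylbenzyl on the same nitrogen would separate these parts.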